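Furan-2-yl to furan-3-yl on the amide carbonyl

The source may report more compounds than this note shows. Statements on the series, on what has been measured and on what is new or still open speak of the compounds shown alone.

Of the compounds shown here, two have numbers so far in a functional assay on NCI-H460 cells (Homo sapiens) for inhibition, read by colorimetric assay and sulforhodamine B assay, with a stated time of 48 h; a higher number here means a weaker inhibitor of growth, a lower number a stronger inhibitor of growth. Compound 1 `CCCCCCCCCCCC[C@@H](O)[C@H]1CC[C@H]([C@H](O)CCCCCCCCCCNC(=O)c2cccs2)O1` gives 2290 nM. Compound 2 `CCCCCCCCCCCC[C@@H](O)[C@H]1CC[C@H]([C@H](O)CCCCCCCCCCNC(=O)c2ccco2)O1` gives 18200 nM, the higher of the two numbers and so the weaker inhibitor of growth in this pair.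

Compound 3 `CCCCCCCCCCCC[C@@H](O)[C@H]1CC[C@H]([C@H](O)CCCCCCCCCCNC(=O)c2ccoc2)O1` keeps the shared core and differs from compound 2 only in the ring on the amide carbonyl: furan-3-yl in place of furan-2-yl on a carbonyl carbon. The two have the same atoms, joined differently.

Within the data shown here, one measured step bears on this change: a 7.9-fold higher number from compound 1 to compound 2 (0.90 log units; beyond the scatter), with furan-2-yl in place of thiophen-2-yl on a carbonyl carbon. That modest step lies beyond the scatter and shows that the read-out can respond to a change of ring here. Among the measured compounds shown here, it is a different change, however, and no measured pair compares furan-2-yl with furan-3-yl. A smaller step is expected, with its direction poorly defined. The estimate is a 1.8-fold lower number from compound 2 to compound 3 (0.26 log units; within the scatter), an expected step close to the scatter. For compound 3 the estimated value is 10000 nM, with an expected range of 3000 nM to 26000 nM.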

Compound 3, concentration for 50% growth inhibition: 100000 nM
The estimate for compound 3 lay 10-fold (1.00 log units) below the measured number; the whole stated range lies below it.
By their numbers in this assay, from the lowest: compound 1; then compound 2; then compound 3.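

In this assay furan-3-yl in place of furan-2-yl on the carbonyl carbon gives a clear loss (a 5.5-fold higher number from compound 2 to compound 3 (0.74 log units; beyond the scatter)), so the read-out responds to a change between two isomeric rings with the same atoms and the same counted donors and acceptors, not only to the exchange of one ring for another. Measured against thiophen-2-yl, furan-3-yl gives a large step (a 44-fold higher number from compound 1 to compound 3 (1.64 log units; beyond the scatter)), and compound 3 is the weakest inhibitor of growth of the three, with both of its steps beyond the scatter. Among these three compounds, the amide ring therefore sets the read-out over a wide span while the rest of the structure stays fixed, and no measurement at hand accounts for the difference.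

From the compounds shown here alone, whether thiophen-3-yl on the same carbonyl carbon would lie close to thiophen-2-yl or would show a loss like the one seen between the two furans remains open. Also open is how a phenyl or pyridin-3-yl group at this place would rank against the three rings shown.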